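The source may report more compounds than this note shows. Statements on the series, on what has been measured and on what is new or still open speak of the compounds shown alone.

Three analogues built on one shared core have been measured so far. Compound 1 `C=C1CC(COc2ccc3cccc(O)c3n2)(c2ccccc2)OC1=O` gives 3090 nM in a functional assay on PC-3 cells (Homo sapiens) for antiproliferative activity; a higher number here means a weaker inhibitor of growth, a lower number a stronger inhibitor of growth. Compound 2 `C=C1CC(COc2cccc3ccccc23)(c2ccccc2)OC1=O` gives 4070 nM in this assay, and compound 3 `C=C1CC(COc2cccc3ccc(C)nc23)(c2ccccc2)OC1=O` gives 2950 nM. Compound 3 carries the lowest number of the three, yet its gaps to compound 1 and to compound 2 both lie within the usual scatter, so the three cannot be ranked against each other on these results. Compound 4 `C=C1CC(COc2cccc3cccnc23)(c2ccccc2)OC1=O` differs from compound 3 by one change: hydrogen in place of methyl on an aromatic carbon. Among the compounds with values here, no measured pair shows the effect of such a change here. The step of a 1.1-fold higher number from compound 3 to compound 4 (0.05 log units; within the scatter) is expected to stay within the scatter. Compound 4 is therefore estimated at 3300 nM, with a range from 1500 nM to 7000 nM.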

Compound 4, concentration for 50% growth inhibition: 1580 nM
Estimate against measurement, compound 4: 2.1-fold (0.32 log units) above; the measured number falls inside the stated range.
By their numbers in this assay, from the lowest: compounds 4, 3, 1 and 2 (each within the scatter of the next, the first and the last beyond it).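

Within the data shown here, this is the first pair that differs in one place, and it isolates the methyl next to the ring nitrogen: hydrogen there gives a 1.9-fold lower number from compound 3 to compound 4 (0.27 log units; within the scatter) in this assay. On this core, then, the methyl can be exchanged for hydrogen without a step that stands clear of the scatter. Nothing at hand explains this step. Still open, going by these compounds, is whether a larger change at this carbon, such as an amine, a chlorine atom or a longer chain like ethyl, would move the number beyond the scatter.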